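This account rests on a few compounds, and the source may have more. Where it says the series, first, only, none or still open, it means among the compounds named here.

Measured so far in a functional assay on CHO-K1 cells with Glucose-dependent insulinotropic receptor (Homo sapiens) as the target, read by a luciferase reporter, with a stated time of 5 h; a higher number here means a larger maximal response, a lower number a smaller maximal response:

Compound 1, `CC(C)OC(=O)N1CCC(Oc2cccc3c2CCN3c2ccc(S(C)(=O)=O)cc2)CC1`, gives 70%.
Compound 2, `CC(C)OC(=O)N1CCC(Oc2ncnc3c2CCN3c2ccc(S(C)(=O)=O)cc2F)CC1`, gives 91%.
Compound 3, `CC(C)OC(=O)N1CCC(Oc2ncnc3c2CCN3c2ccc(S(C)(=O)=O)cc2)CC1`, gives 154%.

Compound 2 stands second highest of these three numbers: compound 1 lies below it and compound 3 above it, both gaps beyond the usual scatter. Among the compounds with values here, the one measured step between two compounds that differ in a single place is a number 63 percentage points higher from compound 2 to compound 3 (beyond the scatter), which goes with hydrogen in place of fluoro on an aromatic carbon.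

Compound 4, `CC(C)OC(=O)N1CCC(Oc2ncnc3c2CCN3c2ccc(-c3nccs3)cc2F)CC1`, differs from compound 2 in another place: 1,3-thiazol-2-yl in place of methylsulfonyl on an aromatic carbon. Within the data shown here, no measured step bears on this exchange, since all three measured compounds carry the methylsulfonyl group, and the fluoro group of compound 2 is kept in compound 4. The measured step from compound 2 to compound 3 therefore gives no guide here, and the expected size of the step in this assay can only be wide.

Compound 4 is estimated at 85%, with a range from 35% to 135%. This estimate means an expected step of a number 6 percentage points lower from compound 2 to compound 4 (within the scatter), close to compound 2, held loosely.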

Compound 4, largest response reached (reported as percent of maximum), in percent of the reference or control that the assay uses: 74%
The estimate for compound 4 lay 11 percentage points above the measured number; the range from low to high includes it.
By their numbers in this assay, from the lowest: compounds 1 and 4 (each within the scatter of the next); then compound 2; then compound 3.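

In this assay, within the data shown here, the exchange of methylsulfonyl for 1,3-thiazol-2-yl, made with the fluoro group kept, goes with a number 17 percentage points lower from compound 2 to compound 4 (beyond the scatter) and is the first measured change at this place, para to a large group on the carbon-only aromatic ring. The response therefore depends on the group here as well as on the fluoro group, although a sizeable maximal response remains with the five-membered aromatic ring in place. Both groups count 2 hydrogen-bond acceptors and 0 donors, so matching these counts did not keep the number unchanged, and nothing measured here explains the drop. Going by these compounds, it remains open whether the same exchange would cost as much with hydrogen in place of fluoro. A nitrile or a carboxamide at this place could also show whether other groups give a larger response than 1,3-thiazol-2-yl.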